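The source may hold more compounds than are shown below. What is called first, only, known or untested is meant among the compounds shown, and "the series" means these compounds.

Measured so far:
Compound 1, `CCCCCCCCCCc1ccc(-c2noc(C3CCNCC3)n2)cc1`, in an assay on HeLa cells for inhibition of sphingosine-1-phosphate transporter SPNS2 (Mus musculus), read by LC-MS, tested at 2 uM; a lower number here means less inhibition, a higher number more inhibition at the concentration tested (going by the name of the read-out): 66%
Compound 2, `CCCCCCCCCCc1ccc(-c2noc(CCCN3CCCCC3)n2)cc1`: 0%
Compound 3, `CCCCCCCCCCc1ccc(-c2noc(CC(O)CN3CCCC3)n2)cc1`: 21%

Compound 3 stands second highest of these three numbers in this assay: it sits well below compound 1, as shown by a number 45 percentage points lower from compound 1 to compound 3 (beyond the scatter), and above compound 2, as shown by a number 21 percentage points higher from compound 2 to compound 3 (beyond the scatter). Compound 1, with its ring amine attached directly to the shared core, is the only one of the three with strong inhibition; both compounds with a chain between core and amine are weaker.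

Compound 4 is `CCCCCCCCCCc1ccc(-c2noc(CC(O)CNCC)n2)cc1`. It differs from compound 3 in one place: ethylamino in place of pyrrolidin-1-yl on a saturated chain carbon, two bonds along the chain from an oxygen on a saturated carbon. Among the measured compounds shown here, no measured step changes a ring amine into an open-chain amine while leaving the rest untouched, so no step bears on this change directly. The nearest is the modest step of a number 21 percentage points higher from compound 2 to compound 3 (beyond the scatter), which altered both the chain and the ring amine at once. On that basis only a small step is expected, possibly a slight loss or none beyond the scatter. Compound 4 is therefore expected to give about 15%, in a range from 0% to 35%. The expected step is a number 6 percentage points lower from compound 3 to compound 4 (within the scatter).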

Compound 4, a percentage reported as inhibition, at one concentration (the size of the read-out at that concentration, not a potency): 5%
Compound 4: middle estimate off by 10 percentage points, on the high side; low and high end bracket the measured number.
By their numbers in this assay, from the lowest: compounds 2 and 4 (each within the scatter of the next); then compound 3; then compound 1.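

In this assay the amine at the end of the hydroxy-bearing chain clearly matters: with the rest of the molecule unchanged, ethylamino in place of pyrrolidin-1-yl gives a number 16 percentage points lower from compound 3 to compound 4 (beyond the scatter) and is the first step shown that alters this group alone. The step of a number 5 percentage points higher from compound 2 to compound 4 (within the scatter) means no difference can be claimed for that change of chain and amine together, and the step of a number 61 percentage points lower from compound 1 to compound 4 (beyond the scatter) leaves the directly attached piperidin-4-yl far ahead of this open-chain amine. No measurement shown explains why the ring amine gives the higher number.

Still open, from the compounds shown here alone, is whether piperidin-1-yl on the same 2-hydroxypropyl chain would match pyrrolidin-1-yl, which would also help separate the effect of the hydroxy group from that of the amine. Also open, going by these compounds, is how diethylamino, an open-chain amine without the amine hydrogen, would compare with ethylamino and pyrrolidin-1-yl.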